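Fluoro for methyl on the sulfonamide ring of compound 1

This account rests on a few compounds, and the source may have more. Where it says the series, first, only, none or still open, it means among the compounds named here.

Compound 1 `Cc1ccc(S(=O)(=O)Nc2ccc(CNC(=O)CC3c4ccccc4N=C(N4CCCCC4)N3c3ccccc3)cc2)cc1` gives 170 nM in an assay on HEK293 cells for inhibition of Voltage-dependent T-type calcium channel subunit alpha-1G (Homo sapiens) (a higher number here means a weaker inhibitor, a lower number a stronger inhibitor), the lowest of the three numbers recorded. Compound 3 `COC(=O)CC1c2ccccc2N=C(Nc2ccc(-c3ccccc3)cc2)N1CCCCCN` gives 300 nM, within the scatter of compound 1, while compound 2 `COC(=O)CC1c2ccccc2N=C(Nc2ccc(-c3ccccc3)cc2)N1CCCCCNC(=O)OC(C)(C)C` gives 370 nM, beyond it. Among the measured compounds shown here, the one measured step, a 1.2-fold lower number from compound 2 to compound 3 (0.09 log units; within the scatter), removes a tert-butoxycarbonyl group and does not touch a ring substituent. Compound 4 `O=C(CC1c2ccccc2N=C(N2CCCCC2)N1c1ccccc1)NCc1ccc(NS(=O)(=O)c2ccc(F)cc2)cc1` differs from compound 1 by fluoro in place of methyl on an aromatic carbon. For the measured compounds named here, no recorded step bears on this exchange, so the expected change in this assay is no change at the digits printed from compound 1 to compound 4 (within the scatter), none beyond the scatter. Compound 4 is therefore estimated at 170 nM, with a range from 70 nM to 400 nM.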

Compound 4, half-maximal inhibitory concentration: 110 nM
Estimate against measurement, compound 4: 1.5-fold (0.19 log units) above, and the stated range covers the measured number.
By their numbers in this assay, from the lowest: compounds 4, 1, 3 and 2 (each within the scatter of the next, the first and the last beyond it).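

Among the compounds shown here, the exchange of 4-methylphenyl for 4-fluorophenyl gives the first measured step at this ring position, and in this assay it reads a 1.5-fold lower number from compound 1 to compound 4 (0.19 log units; within the scatter). On this aromatic carbon, then, fluoro and methyl are not told apart by this measurement. Nothing at hand accounts for the step. From the compounds shown here alone, whether chloro, methoxy, trifluoromethyl or an amine on the same carbon would also stay within the scatter of compound 1 remains open. So does the result of plain hydrogen there, with neither fluoro nor methyl on the ring.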